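Distal ring changes on a shared core, compounds 1 to 4

This account rests on a few compounds, and the source may have more. Where it says the series, first, only, none or still open, it means among the compounds named here.

Measured in an assay on mitochondria (strain BALB/c) for inhibition of glycerol-3-phosphate acyltransferase 1, mitochondrial (Mus musculus), read by scintillation counting, with a stated time of 10 min; on this read-out lower numbers stand for stronger inhibition and higher numbers for weaker inhibition:
compound 1 `CCCCCCCCS(=O)(=O)Nc1ccc(-c2cccc(Cl)c2)cc1C(=O)O` gives 8900 nM
compound 2 `CCCCCCCCS(=O)(=O)Nc1ccc(-c2ccc(CCCC)cc2)cc1C(=O)O` gives 9000 nM
compound 3 `CCCCCCCCS(=O)(=O)Nc1ccc(-c2ccccc2-c2ccccc2)cc1C(=O)O` gives 10100 nM

On the numbers shown, compound 3 sits at the high end of the three, with compound 2 nearest and compound 1 furthest, yet both gaps are within the scatter, so no ordering among the three compounds can be claimed.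

Compound 4 `CCCCCCCCS(=O)(=O)Nc1ccc(-c2ccccc2O)cc1C(=O)O` is not yet measured. Going from compound 3 to compound 4, the change is hydroxy in place of phenyl on an aromatic carbon, on an aromatic carbon of a six-membered aromatic ring of carbon only, ortho to a large group.

Among the measured compounds shown here, the one measured step that bears on a change at this distal ring is a 1.0-fold higher number from compound 1 to compound 2 (0.00 log units; within the scatter), which exchanged one group on that ring for another without any shift beyond the scatter. Compound 3, carrying phenyl there, gives a number indistinguishable from compound 1 and compound 2. For the measured compounds named here, the exchange in compound 4 is of a different kind and no step of its sort is on record, so the expectation rests on this flat picture alone: a step of a 1.1-fold lower number from compound 3 to compound 4 (0.03 log units; within the scatter) in this assay is expected, that is, none beyond the scatter.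

Compound 4 is therefore estimated at 9500 nM, within 4000 nM to 25000 nM.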

Compound 4, half-maximal inhibitory concentration: 61700 nM
Beside the measured number, compound 4's estimate is 6.5-fold (0.81 log units) below it, and the stated range ends below it.
By their numbers in this assay, from the lowest: compounds 1, 2 and 3 (each within the scatter of the next); then compound 4.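

In this assay, among the compounds shown here, the distal ring had tolerated every exchange among compounds 1, 2 and 3 within the scatter, and the hydroxy group ortho to a large group is the first change at this position to move the number beyond it, with a 6.1-fold higher number from compound 3 to compound 4 (0.79 log units; beyond the scatter) for hydroxy in place of phenyl. The other two comparisons agree in direction and size, with a 6.9-fold higher number from compound 2 to compound 4 (0.84 log units; beyond the scatter) and a 6.9-fold higher number from compound 1 to compound 4 (0.84 log units; beyond the scatter), so 2-hydroxyphenyl weakens inhibition relative to 3-chlorophenyl and 4-butylphenyl as well, and this position is not indifferent to every substituent. No measurement at hand accounts for this rise in the number.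

The compounds shown do not separate the effect of adding hydroxy from that of removing phenyl, since this exchange does both at once, and a methoxy group or a plain hydrogen at the same place would begin to tell these apart. Also open, from the compounds shown here alone, is whether the step is specific to this place on the ring or to hydroxy itself, which an amine or a carboxylic acid at the same place, or hydroxy elsewhere on the ring, would address.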